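This account rests on a few compounds, and the source may have more. Where it says the series, first, only, none or still open, it means among the compounds named here.

Series notes. The shared core is seen in compound 3 `Oc1nncc2cncn12`. In a functional assay for inhibition, with Homo sapiens as the target (on this read-out lower numbers stand for stronger inhibition and higher numbers for weaker inhibition), compound 3 returns no number, only a limit, > 48000 nM. Compound 1 `COCc1nc(Br)c2cnnc(O)n12` in this assay also returns only a limit, > 48000 nM. Compound 2 `COCc1ncc2cnnc(NCCN(C)C)n12` in this assay likewise returns only a limit, > 48000 nM. Compound 3 therefore stands where every value shown stands, at the limit of > 48000 nM in this assay, at which 3 of the 3 values shown sit, and there is no number against which it could be ranked. Within the data shown here, no two measured compounds differ in a single place, so no measured step is available to calibrate any change.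

Compound 4 `COCc1ncc2cnnc(O)n12` differs from compound 3 by methoxymethyl in place of hydrogen on an aromatic carbon. Compound 1 and compound 2 already carry a methoxymethyl group, and neither gives a number in this assay. No shift beyond the scatter is expected here, and the step from compound 3 to compound 4 in this assay is estimated at a step that the limit leaves unreadable from compound 3 to compound 4. Compound 4 is expected to give 60000 nM in this assay, within 20000 nM to 200000 nM, most probably reported again only as a limit.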

Compound 4, half-maximal inhibitory concentration: > 48000 nM
Compound 4: no number, only a limit; the forecaster's own chance of this, stated with the estimate: 85%; the middle value lies beyond the limit too.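

Compound 4 also returns only a limit, so the steps from compound 1, compound 2 and compound 3 to compound 4 cannot be read, and the series stays without a number: the limit of > 48000 nM in this assay, at which 4 of the 4 values shown sit. The compounds shown leave open which change on the shared core, if any, would give a number in this assay.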